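Replacing thiophen-2-yl with phenyl in compound 1

The source may hold more compounds than are shown below. What is called first, only, known or untested is meant among the compounds shown, and "the series" means these compounds.

In a functional assay on BHK-21 cells (Mesocricetus auratus) for cytotoxicity, read by MTT assay (on this read-out lower numbers stand for higher toxicity in this test and higher numbers for lower toxicity in this test), compound 1 `O=C(c1ccccc1)N1N=C(c2cccs2)CC1c1ccc(Cl)cc1` gives > 300000 nM, which is a limit of the assay and not a number. That places it at the limit of > 300000 nM in this assay, at which 2 of the 3 values shown sit. Compound 2 `O=C(c1ccc([N+](=O)[O-])cc1)N1N=C(c2cccs2)CC1c1ccc(Cl)cc1` gives > 300000 nM, which is also a limit. Nitro in place of hydrogen on an aromatic carbon is therefore a step that the two limits leave unreadable from compound 1 to compound 2. Compound 3 `O=C(c1ccccc1)N1N=C(c2cccs2)CC1c1ccc(F)cc1` gives a true number of 100000 nM. Fluoro in place of chloro on an aromatic carbon is an at least 3.0-fold lower number from compound 1 to compound 3 (0.47 log units; beyond the scatter).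

The next change gives compound 4 `O=C(c1ccccc1)N1N=C(c2ccccc2)CC1c1ccc(Cl)cc1`: phenyl in place of thiophen-2-yl on a carbon with a double bond to nitrogen, (phenyl in place of thiophen-2-yl on a carbon with a double bond to nitrogen). Neither measured step touches this place, so they offer only indirect guidance. Among the measured compounds shown here, the one readable step, an at least 3.0-fold lower number from compound 1 to compound 3 (0.47 log units; beyond the scatter), suggests that a single swap can produce a modest drop, and a similar modest drop is expected here. The assay may again report only a limit. For compound 4 the estimated value is 200000 nM, with an expected range from 70000 nM to 500000 nM. The expected change is an at least 1.5-fold lower number from compound 1 to compound 4 (0.17 log units; that floor lies within the scatter).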

Compound 4, half-maximal cytotoxic concentration: 250000 nM
Estimate against measurement, compound 4: 1.3-fold (0.10 log units) below; the measured number falls inside the stated range.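

Of the steps shown, this is the only one at the carbon with a double bond to nitrogen, and in this assay phenyl in place of thiophen-2-yl gives an at least 1.2-fold lower number from compound 1 to compound 4 (0.07 log units; that floor lies within the scatter), a floor that does not establish a real change. The swap therefore shows no clear effect at this position, although a larger drop stays possible. The value of compound 1 is a limit and not a number: the limit of > 300000 nM in this assay, at which 2 of the 4 values shown sit.

On these data alone, it remains open whether any group at this place can move the number clearly beyond the scatter, for example an aliphatic amine or a carboxylic acid in place of the aromatic ring. As far as these compounds go, it is also open whether the phenyl swap would read the same alongside the 4-fluorophenyl group of compound 3.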